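A few compounds are considered here, and "the series" means these few. Any claim that something is new, unique, unknown or untested is made for them only; others in the source may bear on it.

In a functional assay on KB cells (Homo sapiens) for antiproliferative activity, read by sulforhodamine B assay, with a stated time of 3 days (on this read-out lower numbers stand for an effect already at smaller amounts and higher numbers for an effect only at larger amounts of compound), compound 1 `CCC1=C(O)c2c(oc(-c3ccc(OC)cc3)cc2=O)C(CC)(CC)C1=O` gives 17.7 uM and compound 2 `CCC1=C(O)c2c(oc(-c3ccc(F)cc3)cc2=O)C(CC)(CC)C1=O` gives 33 uM. Compound 3 `CCC1=C(O)c2c(oc(-c3cccc(F)c3)cc2=O)C(CC)(CC)C1=O` gives > 56.2 uM, which is a limit of the assay and not a number. Compound 4 `CCC1=C(O)c2c(oc(-c3ccccc3C)cc2=O)C(CC)(CC)C1=O` carries 2-methylphenyl in place of 3-fluorophenyl on an aromatic carbon next to the ring oxygen (2-methylphenyl in place of 3-fluorophenyl on an aromatic carbon). Among the compounds with values here, no measured compound has this methyl group, so the nearest guides are swaps at the same place: an at least 3.1-fold higher number from compound 1 to compound 3 (0.50 log units; beyond the scatter) and an at least 1.7-fold higher number from compound 2 to compound 3 (0.23 log units; that floor lies within the scatter). Both are only floors, and they give no exact size. The expected change is an at least 1.3-fold lower number from compound 3 to compound 4 (0.12 log units; that floor lies within the scatter), so no shift beyond the scatter is expected. For compound 4 the estimate is 42 uM, with an expected range from 20 uM to 80 uM.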

Compound 4, concentration for half-maximal effect: 40.9 uM
Beside the measured number, compound 4's estimate is 1.0-fold (0.01 log units) above it; the range from low to high includes it.
By their numbers in this assay, from the lowest: compounds 1, 2 and 4 (each within the scatter of the next, the first and the last beyond it). At a limit, above all of these: compound 3.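

Placing 2-methylphenyl on this carbon gives a 1.2-fold higher number from compound 2 to compound 4 (0.09 log units; within the scatter), so it cannot be told apart from 4-fluorophenyl, but a 2.3-fold higher number from compound 1 to compound 4 (0.36 log units; beyond the scatter), so 4-methoxyphenyl keeps a real edge over it. Compared with 3-fluorophenyl the change gives an at least 1.3-fold lower number from compound 3 to compound 4 (0.13 log units; that floor lies within the scatter), which is only a floor. Compound 3 stands at a limit, not a number: the limit of > 56.2 uM in this assay, at which 1 of the 4 values shown sits.

Going by these compounds, it remains open whether an amine or a carboxylic acid on this phenyl ring would shift the number. Also open, on these data alone, is whether 4-methylphenyl would behave like 2-methylphenyl.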